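This account rests on a few compounds, and the source may have more. Where it says the series, first, only, none or still open, it means among the compounds named here.

Compound 1 `O=C1/C(=C/c2ccc(F)cc2)Cc2ccccc21`: in a functional assay on P388 cells (Mus musculus) for inhibition (on this read-out higher numbers stand for weaker inhibition and lower numbers for stronger inhibition), compound 1 gives > 50000 nM, which is a limit of the assay.
Compound 2 `O=C1/C(=C/c2ccc(Br)cc2)Cc2ccccc21`: compound 2 gives > 50000 nM, also a limit of the assay.
Going by the values given here, compound 3 `O=C1/C(=C/c2ccc(F)cc2)CCc2ccccc21`: compound 3 gives 15900 nM, the only number in the set.

Compound 1 and compound 2 share one core; compound 2 carries bromo in place of fluoro on an aromatic carbon. The step that the two limits leave unreadable from compound 1 to compound 2 cannot be read, since both values sit at the limit of > 50000 nM in this assay, at which 2 of the 3 values shown sit. Compound 3 has another core; the difference between the two cores is not broken down here. Compound 4 `O=C1/C(=C/c2ccc(Br)cc2)CCc2ccccc21` repeats the same change on the core of compound 3: bromo in place of fluoro on an aromatic carbon. Among the compounds with values here, no measured pair gives the size of this change, so it is taken as small. For compound 4 a step of a 1.3-fold lower number from compound 3 to compound 4 (0.12 log units; within the scatter) is expected, resting on compound 3 with 15900 nM. Compound 4 is expected at 12000 nM, between 4000 nM and 40000 nM.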

Compound 4, half-maximal inhibitory concentration: 20400 nM
Compound 4: the middle estimate sits 1.7-fold (0.23 log units) below what was measured; low and high end bracket the measured number.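

In this assay, bromo in place of fluoro on an aromatic carbon of the core of compound 3 gives a 1.3-fold higher number from compound 3 to compound 4 (0.11 log units; within the scatter), so the two compounds cannot be told apart on this read-out. This is one readable instance on one core, and it does not show that the change carries across cores. The matching pair on the core of compound 1 cannot be read, as both of its values are limits: the limit of > 50000 nM in this assay, at which 2 of the 4 values shown sit.

On these data alone, only fluoro and bromo appear on the aromatic ring, so how an amine or a carboxylic acid in that place would read remains open. Also open, as far as these compounds go, is whether any substituent on the core of compound 1 would give a number rather than a limit.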